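A few compounds are considered here, and "the series" means these few. Any claim that something is new, unique, unknown or untested is made for them only; others in the source may bear on it.

Compound 1, `O=C(NO)c1cccc(-c2cn([C@H]3C[C@@H](CO)N(Cc4ccccc4)C3)nn2)c1`, and compound 2, `O=C(NO)c1cccc(-c2cn([C@H]3C[C@H](C(=O)O)N(Cc4ccccc4)C3)nn2)c1`, share one core and differ only in the group carried on the saturated ring. In an assay on Sf9 cells for inhibition of histone deacetylase 11 (Homo sapiens), read by fluorescence, tested at 0.5 uM (on this read-out lower numbers stand for less inhibition and higher numbers for more inhibition at the one concentration tested (going by the name of the read-out)), compound 1 gives < 10%, which is a limit of the assay rather than a measured number. In this assay compound 2 likewise gives < 10%, again a limit of the assay and not a number. Where compound 2 stands can thus be told only roughly: its result sits at the limit of < 10% in this assay, at which 2 of the 2 values shown sit, so it shows no inhibition the assay can resolve at the tested concentration, and nothing on the numbers shown separates it from compound 1.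

Compound 3, `O=C(NO)c1cccc(-c2cn([C@H]3C[C@@H](C(=O)O)N(Cc4ccccc4)C3)nn2)c1`, is the next compound to be measured in this assay. How it differs from compound 2: the two compounds have the same atoms and bonds and differ only in configuration as drawn: 1 of 2 stereo elements differ; a stereocentre at a saturated ring carbon is drawn R in compound 2 and S in compound 3. Among the measured compounds shown here, no step between two measured compounds is available here, so the expectation rests on the two limits alone. In this assay a step that the limit leaves unreadable from compound 2 to compound 3 is expected, that is, none beyond the usual scatter. Compound 3 is therefore expected to give an inhibition near 5%, between 0% and 15%, most likely reported once more as a limit.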

Compound 3, a percentage reported as inhibition, at one concentration (the size of the read-out at that concentration, not a potency): 14%
Compound 3: the middle estimate sits 9 percentage points below what was measured; measured number inside the range.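

In this assay, among the compounds shown here, compound 3 is the first of the three compounds to give a number rather than a limit, which makes this saturated ring carbon a place worth watching, though not yet one with a proven effect. Changing only the configuration as drawn gives a number at least 4 percentage points higher from compound 2 to compound 3 (that floor lies within the scatter), and placing carboxy where hydroxymethyl stood gives a number at least 4 percentage points higher from compound 1 to compound 3 (that floor lies within the scatter). Neither step establishes a real change in inhibition, but the first comparison does isolate the stereocentre as the only difference: the fact that compounds 2 and 3 differ only in the configuration as drawn

From the compounds shown here alone, what remains open is whether either change has any true effect on inhibition, since both steps rest on a limit and their floors stay within the usual scatter. Going by these compounds, it is also open how this ring carbon would respond to a different group, such as a primary amine, a methyl ester or a longer chain ending in a carboxylic acid, and whether either configuration would then give a clearer reading.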